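Dropping a Methoxybenzyl Group to Free the Amine

The source may hold more compounds than are shown below. What is called first, only, known or untested is meant among the compounds shown, and "the series" means these compounds.

Of the compounds shown here, three with a shared core have been tested in an assay on HEK293 cells for antagonist activity at Toll-like receptor 9 (Homo sapiens), read by spectrophotometry; a higher number here means a weaker inhibitor, a lower number a stronger inhibitor. Compound 1 `Nc1nc(N2CCN(C3CCCC3)CC2)c2ncn(CCCN3CCCC3)c2n1` carries a free amino group on its core and gives 120 nM in this assay. Compound 3 `CCN1CCN(CCCn2cnc3c(N4CCN(CC)CC4)nc(NC(=O)c4ccccc4)nc32)CC1` carries a benzoyl group on that nitrogen and gives 340 nM. Compound 2 `CCN1CCN(CCCn2cnc3c(N4CCN(C(=O)C5CCCC5)CC4)nc(NCc4ccc(OC)cc4)nc32)CC1` gives only a limit in this assay, namely > 30000 nM, so no number is known for it. Compound 2 thus sits at the limit of > 30000 nM in this assay, at which 1 of the 3 values shown sits, where the assay stops counting.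

Compound 4 `CCN1CCN(CCCn2cnc3c(N4CCN(C(=O)C5CCCC5)CC4)nc(N)nc32)CC1` has not been measured yet. It differs from compound 2 in one place: hydrogen in place of 4-methoxybenzyl on a nitrogen on an aromatic ring. Cut one bond further out, the (4-methoxybenzyl)amino group becomes a plain amino group.

Among the compounds with values here, no step between two measured compounds is known here, so the expectation rests on what the values show. Compound 1, which also carries a free amino group, gives 120 nM. The step of an at least 15-fold lower number from compound 2 to compound 4 (1.17 log units; beyond the scatter) is therefore expected to be large and toward a stronger inhibitor, though compound 2 and compound 4 differ from compound 1 elsewhere, so some uncertainty remains. Compound 4 is expected to give about 2000 nM, within a range from 300 nM to 20000 nM.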

Compound 4, half-maximal inhibitory concentration: > 30000 nM
Compound 4: a limit, no number (the forecaster's own chance of this, stated with the estimate: 20%); middle value at least 15-fold (1.17 log units) away from the limit.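

Compound 4, like compound 2, gives only a limit and not a number, so the step between these two compounds cannot be read: (the limit of > 30000 nM in this assay, at which 2 of the 4 values shown sit). The compounds shown leave open how far each lies beyond that limit in this assay, and so whether hydrogen in place of 4-methoxybenzyl changes inhibition at all.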